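Methoxy to fluoro on the aryl chain of compound 2

The source may report more compounds than this note shows. Statements on the series, on what has been measured and on what is new or still open speak of the compounds shown alone.

Measured so far in a functional assay for inhibition of metabotropic glutamate receptor 5 (Rattus norvegicus), read by fluorescence and calcium flux; on this read-out lower numbers stand for stronger inhibition and higher numbers for weaker inhibition:
compound 1 `O=C(OCc1ccc(F)cc1)c1sc2ncccc2c1-c1ccc(Cl)cc1`: 150 nM
compound 2 `COc1ccc(CCC(=O)c2sc3ncccc3c2-c2ccccc2)cc1`: 8000 nM

Compound 2 stands at the highest of the two numbers shown; compound 1 sits far lower, but the two differ in several places, so only their values are compared here. Compound 3 `O=C(CCc1ccc(F)cc1)c1sc2ncccc2c1-c1ccccc1` differs from compound 2 by fluoro in place of methoxy on an aromatic carbon. Going by the values given here, no step between measured compounds covers this change, so the expectation rests on compound 2 alone. A small step toward a lower number, at most near the edge of the scatter, is expected, a 1.6-fold lower number from compound 2 to compound 3 (0.20 log units; within the scatter). Compound 3 is estimated at 5000 nM, with a range from 1500 nM to 15000 nM.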

Compound 3, half-maximal inhibitory concentration: 2100 nM
Compound 3: the middle estimate sits 2.4-fold (0.38 log units) above what was measured, and the stated range covers the measured number.
By their numbers in this assay, from the lowest: compound 1; then compound 3; then compound 2.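

In this assay, fluoro in place of methoxy gives a 3.8-fold lower number from compound 2 to compound 3 (0.58 log units; beyond the scatter) as a modest step that lies beyond the scatter. This position, on the aromatic ring at the end of the chain and para to a large group, therefore responds to a single substituent change. No measurement shown gives a reason for this step.

As far as these compounds go, an unsubstituted phenyl, a chloro group or an amine at this position remains open, as does a longer chain. Also open, from the compounds shown here alone, is whether the same change would carry over to the ester series of compound 1.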